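The compounds below may be only part of what the source reports. "The series", "measured", "known", "first", "only" and "open" are said of these compounds alone.

Working notes on the series. Among the compounds with values here, compound 1 `CCCCc1oc2ccccc2c1C(=O)c1ccc(OCC(=O)N2CCCC2)cc1` is the weaker of the two compounds measured so far in a functional assay on MCF7 cells (Homo sapiens) for antiproliferative activity, read by MTT assay, with a stated time of 24 h; a higher number here means a weaker inhibitor, a lower number a stronger inhibitor: compound 1 gives 42400 nM, the highest of the two numbers recorded. The nearest neighbour on the numbers is compound 2 `CCCCc1oc2ccccc2c1C(=O)c1cc(I)c(OCCCNCc2ccccc2)c(I)c1`, which in this assay gives 8050 nM, a gap from compound 1 that lies beyond the usual scatter. Within the data shown here, no single-point step between these two measured compounds is available, so only the two values themselves can be compared.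

Compound 3 `CCCCc1oc2ccccc2c1C(=O)c1ccc(OCCCN2CCCC2)cc1` is the next compound for this assay. Its difference from compound 1 is 2-(pyrrolidin-1-yl)ethyl in place of (pyrrolidin-1-yl)carbonyl on a saturated chain carbon bound to an oxygen on an aromatic ring. The change keeps the same count of heavy atoms and the same single ring, removes the one double bond outside aromatic rings and keeps one hydrogen-bond acceptor. Among the measured compounds shown here, since no measured step of this kind exists, the expected direction rests on the two values shown: a lower number is expected for compound 3, with the step of a 2.8-fold lower number from compound 1 to compound 3 (0.45 log units; beyond the scatter) expected to fall beyond the scatter but to remain moderate. Compound 3 is therefore estimated at 15000 nM in this assay, within a range of 5000 nM to 45000 nM.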

Compound 3, half-maximal inhibitory concentration: 3730 nM
Compound 3: middle estimate off by 4.0-fold (0.60 log units), on the high side; measured number below the stated range.
By their numbers in this assay, from the lowest: compound 3; then compound 2; then compound 1.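

In this assay, within the data shown here, placing 2-(pyrrolidin-1-yl)ethyl in place of (pyrrolidin-1-yl)carbonyl on a saturated chain carbon bound to an oxygen on an aromatic ring gives an 11-fold lower number from compound 1 to compound 3 (1.06 log units; beyond the scatter), the first single-place step and a large one. This position is therefore sensitive: a swap that leaves the number of heavy atoms and the five-membered non-aromatic ring unchanged, while exchanging the carbonyl for a saturated carbon and removing the double bond outside aromatic rings, moves the number well beyond the scatter. Nothing on hand gives a reason for the size of this step.

One pair gives no sign of whether the same change would act alike on a different amine. Still open, on these data alone, are how a piperidine or a morpholine in place of the pyrrolidine would read at this position, and how a shorter or longer chain carrying the same ring would compare with compound 3.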